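The source may report more compounds than this note shows. Statements on the series, on what has been measured and on what is new or still open speak of the compounds shown alone.

Of the compounds shown here, three have so far been read in a physicochemical assay for solubility, read by nephelometry, measured as kinetic solubility, at pH 6.5; on this read-out lower numbers stand for lower solubility and higher numbers for higher solubility. Compound 1 `OC(c1ccc(Cl)cc1)(c1cccnc1)c1ccccc1Cl` gives 3.1 ug/mL, compound 2 `CC(C)Oc1ccc(C(O)(c2ccc(C(F)(F)F)cc2)c2cccnc2)cc1` gives 1.6 ug/mL, and compound 3 `N#Cc1ccc(C(O)(c2ccc(C(F)(F)F)cc2)c2cccnc2)cc1` gives 6.3 ug/mL. That last number is the highest of the three, and its gap to each of the other two lies beyond the scatter. Compound 4 `OC(c1ccc(C(F)(F)F)cc1)(c1cccnc1)c1ccc(Cl)cc1F`, not yet measured, has 4-chloro-2-fluorophenyl in place of 4-cyanophenyl on a saturated chain carbon bound to two aromatic carbons and an oxygen on a saturated carbon. Among the measured compounds shown here, one measured step bears on this change, since it also concerns the cyano group: a 3.9-fold higher number from compound 2 to compound 3 (0.60 log units; beyond the scatter), a modest step with cyano in place of isopropoxy. Compound 1, which has chlorine on its aromatic rings and no cyano group, gives 3.1 ug/mL. A modest drop in this assay is therefore expected, no larger than that measured step. The expected step is a 2.3-fold lower number from compound 3 to compound 4 (0.35 log units; beyond the scatter). For compound 4 the estimated value is 2.8 ug/mL, with an expected range from 1.2 ug/mL to 6.5 ug/mL.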

Compound 4, solubility: < 1.6 ug/mL
Compound 4 gave a limit, no number; the forecaster's own chance of this, stated with the estimate: 5%; middle value at least 1.7-fold (0.24 log units) from the limit.
By their numbers in this assay, from the lowest: compounds 2 and 1 (each within the scatter of the next); then compound 3.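

In this assay, 4-chloro-2-fluorophenyl in place of 4-cyanophenyl on a saturated chain carbon bound to two aromatic carbons and an oxygen on a saturated carbon gives an at least 3.9-fold lower number from compound 3 to compound 4 (0.59 log units; beyond the scatter). The earlier step, a 3.9-fold higher number from compound 2 to compound 3 (0.60 log units; beyond the scatter), changed only a group on an aromatic carbon, whereas this one exchanges the whole ring at this position and also moves the read-out beyond the scatter. The reading of compound 4 is a limit of the assay and not a number: the limit of < 1.6 ug/mL in this assay, at which 1 of the 4 values shown sits.

The compounds shown do not separate the effect of losing the nitrile from that of adding the chlorine or the fluorine, and the exact size of the step stays open. They also leave open how a ring carrying an amine or a carboxylic acid would read at this position in this assay.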